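Removing the chloro from the benzyl arm of compound 1

The compounds below may be only part of what the source reports. "The series", "measured", "known", "first", "only" and "open" are said of these compounds alone.

Compound 1 `CN(Cc1ccc(Cl)cc1)Cc1ccccc1CNc1ccnc2cc(Cl)ccc12` was measured in a physicochemical assay for acid dissociation, and gave 9.6. Among the compounds with values here, compound 2 `CN(Cc1ccc(N(C)C)cc1)Cc1cccc(CNc2ccnc3cc(Cl)ccc23)c1` is the only other compound with a number here; in this assay compound 2 gave 9.67, and the two values lie within the scatter of each other, so no order between them can be claimed. Compound 3 `CN(Cc1ccccc1)Cc1ccccc1CNc1ccnc2cc(Cl)ccc12` differs from compound 1 by hydrogen in place of chloro on an aromatic carbon. Within the data shown here, no measured pair shows this change, so the step from compound 1 to compound 3 is expected to be a number 0.10 log units higher from compound 1 to compound 3 (within the scatter), not beyond the scatter. Compound 3 is therefore estimated at 9.7, in the range 9.4 to 10.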

Compound 3, acid dissociation constant: 9.85
The estimate for compound 3 lay 0.15 log units below the measured number, within the range that was stated.
By their numbers in this assay, from the lowest: compounds 1, 2 and 3 (each within the scatter of the next).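

Within the data shown here, this is the first measured pair that isolates the chloro of the 4-chlorobenzyl arm: in this assay, hydrogen in its place gives a number 0.25 log units higher from compound 1 to compound 3 (within the scatter). At this position, on this core, the loss of that single chlorine therefore cannot be told apart from repeat measurement. No independent evidence on this result is available.

Going by these compounds, whether a nitrile, a trifluoromethyl or a carboxylic acid on the same aromatic carbon would give a step beyond the scatter remains open. So does whether this exchange would read the same on another core.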